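Arylamino to propyl on the amide nitrogen

A few compounds are considered here, and "the series" means these few. Any claim that something is new, unique, unknown or untested is made for them only; others in the source may bear on it.

Compound 2 `O=C(Nc1sc2c(c1C(=O)NNc1ccc(Cl)cc1)CCCCC2)NS(=O)(=O)c1ccccc1` stands only at a limit in a functional assay on EKVX cells (Homo sapiens) for inhibition, with a stated time of 48 h; a higher number here means a weaker inhibitor of growth, a lower number a stronger inhibitor of growth: compound 2 gives > 100000 nM, a limit of the assay rather than a number. Compound 1 `NNC(=O)c1c(NC(=O)NS(=O)(=O)c2ccccc2)sc2c1CCCCC2` is likewise reported only as a limit, > 100000 nM. For the measured compounds named here, the one measured step, a step that the two limits leave unreadable from compound 1 to compound 2, is therefore unreadable, and the limit of > 100000 nM in this assay, at which 2 of the 2 values shown sit, is all the evidence at hand. Compound 3 `CCCNC(=O)c1c(NC(=O)NS(=O)(=O)c2ccccc2)sc2c1CCCCC2` differs from compound 2 by propyl in place of (4-chlorophenyl)amino on an amide-type nitrogen. With no readable step to lean on, the change is expected to be a step that the limit leaves unreadable from compound 2 to compound 3. Compound 3 is estimated at 120000 nM, between 30000 nM and 500000 nM, most probably again a limit.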

Compound 3, concentration for 50% growth inhibition: 6200 nM
Compound 3: the middle estimate sits 19-fold (1.29 log units) above what was measured, outside the stated range (below it).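

At this amide-type nitrogen, replacing the amino-type substituent with a simple alkyl chain gives the first readable growth inhibition in this assay, where compound 3 gives 6200 nM. The change registers from either earlier compound: an at least 16-fold lower number from compound 2 to compound 3 (1.20 log units; beyond the scatter), and an at least 16-fold lower number from compound 1 to compound 3 (1.20 log units; beyond the scatter). Both steps start from a limit, so each fixes only a minimum size: the limit of > 100000 nM in this assay, at which 2 of the 3 values shown sit.

From the compounds shown here alone, whether propyl itself matters or any alkyl group would serve remains open. A shorter ethyl group, a longer chain such as hexyl, or a benzyl group on this nitrogen could separate these possibilities.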